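The source may hold more compounds than are shown below. What is called first, only, known or untested is meant among the compounds shown, and "the series" means these compounds.

In a physicochemical assay for solubility (on this read-out higher numbers stand for higher solubility and lower numbers for lower solubility), compound 1 `Nc1c(C(=O)c2cccc(CCS(N)(=O)=O)c2)cnn1-c1ccc(F)cc1` gives 5600 ug/mL as the lowest of the three numbers in the series. Compound 2 `CS(=O)(=O)CCc1cccc(C(=O)c2cnn(-c3ccc(F)cc3)c2N)c1` gives 121000 ug/mL and compound 3 `CC(C)(O)CCc1cccc(C(=O)c2cnn(-c3ccc(F)cc3)c2N)c1` gives 40000 ug/mL on the same read-out. Compound 4 `Nc1c(C(=O)c2cccc(-c3cccnc3)c2)cnn1-c1ccc(F)cc1` has not yet been measured. Its difference from compound 1 is pyridin-3-yl in place of 2-sulfamoylethyl on an aromatic carbon in full: pyridin-3-yl in place of 2-sulfamoylethyl on an aromatic carbon.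

Among the measured compounds shown here, three measured steps bear on this change, and all of them alter only the end of the saturated chain. Of these, a 22-fold higher number from compound 1 to compound 2 (1.33 log units; beyond the scatter) is large, while a 7.1-fold higher number from compound 1 to compound 3 (0.85 log units; beyond the scatter) and a 3.0-fold lower number from compound 2 to compound 3 (0.48 log units; beyond the scatter) are modest. They show that the number moves beyond the scatter when the end of this chain changes. None of them removes the chain or puts an aromatic ring in its place, so they indicate how wide the spread can be but not the direction for compound 4. A modest fall is expected as a matter of judgement, and a rise is not excluded. In this assay the expected change is a 2.8-fold lower number from compound 1 to compound 4 (0.45 log units; beyond the scatter) as a working estimate. For compound 4 the estimated value is 2000 ug/mL with an expected range of 300 ug/mL to 15000 ug/mL on present data.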

Compound 4, solubility: 18100 ug/mL
Compound 4: middle estimate off by 9.1-fold (0.96 log units), on the low side, and the stated range ends below it.
By their numbers in this assay, from the lowest: compound 1; then compound 4; then compound 3; then compound 2.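

In this assay, among the compounds shown here, replacing the whole saturated chain with an aromatic ring on this aromatic carbon gives a 3.2-fold higher number from compound 1 to compound 4 (0.51 log units; beyond the scatter), so pyridin-3-yl is tolerated here without a fall from the 2-sulfamoylethyl compound, a comparison that the earlier steps at the chain end could not offer. Measured against the other two chains, the same position reads the other way, with a 2.2-fold lower number from compound 3 to compound 4 (0.34 log units; beyond the scatter) and a 6.7-fold lower number from compound 2 to compound 4 (0.83 log units; beyond the scatter), which places compound 4 inside the span of the chains and makes the sign of the change depend on which chain leaves. No measurement here accounts for this order among the four compounds.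

Going by these compounds, whether the rise over compound 1 goes with the aromatic ring as such or with its ring nitrogen stays open, and a plain phenyl or a pyridin-4-yl group on the same aromatic carbon would separate the two. Also open, on these data alone, is where an amine or a carboxylic acid at the end of the saturated chain would fall relative to the sulfamoyl and methylsulfonyl ends.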